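A few compounds are considered here, and "the series" means these few. Any claim that something is new, unique, unknown or untested is made for them only; others in the source may bear on it.

Measured so far in a functional assay on MV4-11 cells (Homo sapiens) for antiproliferative activity, read by luminescence and CellTiter-Glo, with a stated time of 72 h; on this read-out higher numbers stand for weaker inhibition and lower numbers for stronger inhibition:
- compound 1 `COc1ccc(Cn2nc(Nc3cccc(C(C)C)c3)c3ccc(-c4c(C)noc4C)cc32)cc1`: 8100 nM
- compound 2 `COc1ccc(Cn2nc(Nc3ccc(F)cc3OC)c3cc(-c4c(C)noc4C)ccc32)cc1`: "not determined" (no result reported)
- compound 3 `CNc1cc(-c2ccc3cnn(Cc4ccc(OC)cc4)c3c2)cn(C)c1=O`: 2700 nM

Compound 3 holds the lowest of the two numbers in this assay; the nearest is compound 1, whose higher value lies beyond the scatter. Compound 2 gives no number to compare. Compound 4 `CNc1cc(-c2ccc3cnn(CC4CC4)c3c2)cn(C)c1=O` is not yet measured. Its difference from compound 3: cyclopropyl in place of 4-methoxyphenyl on a saturated chain carbon bound to an aromatic nitrogen. Within the data shown here, no measured pair in the set shows this change, so the step stands without precedent. Since the change keeps the core of compound 3 and alters only the group on the saturated chain carbon bound to an aromatic nitrogen, the expected step in this assay is small, a mild weakening or none beyond the scatter, as a 1.3-fold higher number from compound 3 to compound 4 (0.11 log units; within the scatter). Compound 4 is expected to give about 3500 nM, between 1200 nM and 10000 nM.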

Compound 4, half-maximal inhibitory concentration: 3450 nM
Compound 4: the middle estimate sits 1.0-fold (0.01 log units) above what was measured; low and high end bracket the measured number.
By their numbers in this assay, from the lowest: compounds 3 and 4 (each within the scatter of the next); then compound 1.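

In this assay, cyclopropyl in place of 4-methoxyphenyl on a saturated chain carbon bound to an aromatic nitrogen gives a 1.3-fold higher number from compound 3 to compound 4 (0.11 log units; within the scatter). At this position, the six-membered aromatic ring and its oxygen are therefore not needed to hold the number: a three-membered carbon ring, with 3 heavy atoms instead of 8, serves within the scatter. No supporting measurement accounts for this result. From the compounds shown here alone, whether any group here moves the number beyond the scatter remains open, and an amine, a carboxylic acid or a longer chain at this place would test it.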